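Aminothiophene piperazines: aryl swap on the ring nitrogen

The source may report more compounds than this note shows. Statements on the series, on what has been measured and on what is new or still open speak of the compounds shown alone.

Measured so far:
compound 1, `COc1ccc(N2CCN(Cc3csc(N)c3C(=O)c3ccc(Cl)cc3)CC2)cc1`, -1.2%
compound 2, `Nc1scc(CN2CCN(c3ccc([N+](=O)[O-])cc3)CC2)c1C(=O)c1ccc(Cl)cc1`, -12%

Compound 2 gives the lowest of the two numbers in a functional assay on CHO cells with adenosine receptor A1 (Homo sapiens) as the target, read by cAMP accumulation and immunoassay, with a stated time of 6 min, tested at 0.01 uM; a higher number here means a weaker effect of the compound at the concentration tested, a lower number a stronger effect; its nearest neighbour is compound 1, which stands higher by a number 10.8 percentage points lower from compound 1 to compound 2 (beyond the scatter). Within the data shown here, that single step is the only measured change in the set, and it concerns the group on the aromatic carbon, not the aryl attached to the ring nitrogen.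

Compound 3, `Nc1scc(CN2CCN(c3ccccc3C(F)(F)F)CC2)c1C(=O)c1ccc(Cl)cc1`, is the next compound for this assay. It differs from compound 2 by 2-(trifluoromethyl)phenyl in place of 4-nitrophenyl on an amine nitrogen in a ring. Among the measured compounds shown here, no measured step in the set touches a change of this kind; the nitro-to-methoxy step from compound 1 to compound 2 is the only guide, and it was modest. With the aryl on the ring nitrogen replaced as a whole, the direction of the change cannot be read from the two measured compounds.

Compound 3 is therefore expected to sit close to the measured pair, with a step of a number 7 percentage points higher from compound 2 to compound 3 (within the scatter) judged within the scatter, and an estimated value of -5% in this assay, ranging from -22% to 12%.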

Compound 3, a percentage reported as activity, at one concentration (the size of the read-out at that concentration, not a potency): 0%
Compound 3: middle estimate off by 5 percentage points, on the low side; the range from low to high includes it.
By their numbers in this assay, from the lowest: compound 2; then compounds 1 and 3 (each within the scatter of the next).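

With the aryl on the ring nitrogen exchanged as a whole, this assay gives a number 12 percentage points higher from compound 2 to compound 3 (beyond the scatter), so a change at this position can move the read-out beyond the scatter. Against the 4-methoxyphenyl of the other neighbour, the same 2-(trifluoromethyl)phenyl gives a number 1.2 percentage points higher from compound 1 to compound 3 (within the scatter), which leaves compound 2, with its 4-nitrophenyl, as the only one of the three set apart from the others at this single concentration. No supporting information bears on why the 4-nitrophenyl compound stands apart from the other two.

The trifluoromethyl group differs from the nitro and methoxy groups in both identity and its place on the phenyl ring, so these compounds cannot show whether the group or its place governs the read-out. From the compounds shown here alone, it remains open whether an unsubstituted phenyl, or a nitrile or an amine in place of the nitro group, would stay with compound 2 or fall with the other two, and whether the separation of compound 2 would hold across a full concentration range rather than at one concentration.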